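The source may hold more compounds than are shown below. What is called first, only, known or untested is meant among the compounds shown, and "the series" means these compounds.

The compounds measured in an ADME assay on HEK293 cells (Homo sapiens) for cytotoxicity, read by MTT assay, with a stated time of 48 h; a higher number here means a weaker inhibitor, a lower number a stronger inhibitor:

compound 1, `Cc1cc(NC(=O)c2ccc(Cl)cc2)ccc1NS(C)(=O)=O`, with 50300 nM
compound 2, `COc1cc(NC(=O)c2ccc(Cl)cc2)ccc1NS(C)(=O)=O`, with a limit of the assay, > 250000 nM
compound 3, `COc1cc(NC(=O)c2ccc(Cl)c([N+](=O)[O-])c2)ccc1NS(C)(=O)=O`, with 164000 nM

Compound 2 is the weakest of the three compounds here, yet it has no number of its own. In this assay compound 2 gives > 250000 nM, and that is the limit of > 250000 nM in this assay, at which 1 of the 3 values shown sits. The two measured steps both concern the aromatic ring of the shared core: an at least 4.9-fold higher number from compound 1 to compound 2 (0.69 log units; beyond the scatter), and an at least 1.5-fold lower number from compound 2 to compound 3 (0.18 log units; that floor lies within the scatter). Neither step touches the sulfonyl group, so neither bears directly on the change now considered.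

Compound 4, `COc1cc(NC(=O)c2ccc(Cl)cc2)ccc1NS(=O)(=O)C(F)(F)F`, differs from compound 2 by trifluoromethyl in place of methyl on a sulfonyl sulfur. For the measured compounds named here, with no measured step on this position, there is no ground for expecting a step beyond the scatter in either direction in this assay, and the starting point is itself a limit. Compound 4 is therefore expected to sit near the same limit, at an estimated 250000 nM, with a range from 80000 nM to 700000 nM. The step this estimate implies is a number no higher from compound 2 to compound 4 (the limit leaves the size open), expected to lie within the scatter.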

Compound 4, half-maximal inhibitory concentration: > 250000 nM
Compound 4 ended at the assay's limit; the forecaster's own chance of this, stated with the estimate: 60%; the middle value sits exactly at the limit.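

In this assay compound 4 gives > 250000 nM, which is a limit of the assay and not a number. Compound 2 also stands at a limit, so no step can be read from compound 2 to compound 4: the limit of > 250000 nM in this assay, at which 2 of the 4 values shown sit. The compounds shown leave open whether trifluoromethyl in place of methyl on a sulfonyl sulfur changes the number at all.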